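The source may hold more compounds than are shown below. What is called first, only, known or untested is meant among the compounds shown, and "the series" means these compounds.

Values in a functional assay on A549 cells (Homo sapiens) for cytotoxicity, read by MTT assay, with a stated time of 72 h; a higher number here means a weaker inhibitor, a lower number a stronger inhibitor:
Compound 1 `Cc1ccccc1NC(=O)CN1CCN(c2nnc(Cc3ccccc3)c3ccccc23)CC1`: "not active" (no number reported)
Compound 2 `Cc1cccc(Cl)c1NC(=O)CN1CCN(c2nnc(Cc3ccccc3)c3ccccc23)CC1`: 7420 nM
Compound 3 `O=C(CN1CCN(c2nnc(Cc3ccccc3)c3ccccc23)CC1)Nc1cc(C(F)(F)F)ccc1Cl`: 89000 nM

Of the two numbers in this assay, the higher belongs to compound 3, at 89000 nM. Compound 1 gave no number.

Compound 4 `O=C(CN1CCN(c2nnc(Cc3ccccc3)c3ccccc23)CC1)Nc1ccc(F)c(Cl)c1` carries 3-chloro-4-fluorophenyl in place of 2-chloro-5-(trifluoromethyl)phenyl on an amide-type nitrogen.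

For the measured compounds named here, no measured step involves the entering group. Going by the values given here, the only step at this place is a 12-fold higher number from compound 2 to compound 3 (1.08 log units; beyond the scatter), which is large and beyond the scatter. It shows that a change here can move the number substantially, but it gives no direction for the new group. With compound 3 at 89000 nM, the top of the measured numbers, a move toward a lower number is the more likely outcome, and it is expected to be smaller than the measured step. The expected change is a 3.0-fold lower number from compound 3 to compound 4 (0.47 log units; beyond the scatter), and a result without a number, as for compound 1, remains possible. For compound 4 the estimate is 30000 nM, with an expected range of 7000 nM to 120000 nM.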

Compound 4, half-maximal inhibitory concentration: "not active" (no number reported)
The entry for compound 4 holds no number; there is nothing to compare the estimate with.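

In this assay, for the compounds shown here, compound 4 gives "not active" (no number reported) and so no step from compound 3 can be read. Nothing shown bears on this result. The compounds shown leave open how 3-chloro-4-fluorophenyl on the amide-type nitrogen ranks against 2-chloro-5-(trifluoromethyl)phenyl in compound 3.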